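A few compounds are considered here, and "the series" means these few. Any claim that something is new, unique, unknown or untested is made for them only; others in the source may bear on it.

Measured so far in an ADME assay on THP-1 cells (Homo sapiens) for cytotoxicity, read by MTT assay, with a stated time of 72 h; a higher number here means that more compound is tolerated, a lower number that less compound is tolerated
Compound 1 (`CCCCCc1ccc(-c2cn(Cc3cc(-c4ccccc4)no3)nn2)cc1`) reads "not determined" (no result reported)
Compound 2 (`COc1ccc(-c2cn(Cc3cc(-c4ccc(OC)c(OC)c4)no3)nn2)cc1`) reads > 500000 nM as a limit of the assay, not a number
Compound 3 (`COc1ccc(-c2cc(Cn3cc(-c4ccc(OC(F)(F)F)cc4)nn3)on2)cc1OC`) reads 227000 nM

Among the compounds with values here, compound 3, with 227000 nM in this assay, holds the only actual number. Compound 2 ends in a limit and compound 1 has no result.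

Next is compound 4 (`CCCCCc1ccc(-c2cn(Cc3cc(-c4ccc(OC)c(OC)c4)no3)nn2)cc1`), with pentyl in place of trifluoromethoxy on an aromatic carbon, para to a large group (pentyl in place of trifluoromethoxy on an aromatic carbon).

Within the data shown here, the one measured step at this place is an at least 2.2-fold lower number from compound 2 to compound 3 (0.34 log units; beyond the scatter) with trifluoromethyl in place of methyl on an oxygen. It shows that a change here can move the number, but it says nothing direct about pentyl. Compound 1 also carries pentyl, yet it offers no result to compare.

With only an at least 2.2-fold lower number from compound 2 to compound 3 (0.34 log units; beyond the scatter) to go on, a modest move in the same direction is expected for compound 4, and the uncertainty is wide. The expected change is a 2.3-fold lower number from compound 3 to compound 4 (0.36 log units; beyond the scatter) on this single precedent. In this assay the estimate for compound 4 is 100000 nM with an expected range from 30000 nM to 350000 nM as its bounds.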

Compound 4, half-maximal cytotoxic concentration: > 500000 nM
Compound 4 ended at the assay's limit (the forecaster's own chance of this, stated with the estimate: 20%); at least 5.0-fold (0.69 log units) between middle value and limit.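

In this assay, at the aromatic carbon para to a large group, pentyl in place of trifluoromethoxy gives an at least 2.2-fold higher number from compound 3 to compound 4 (0.34 log units; beyond the scatter), so the pentyl chain now has a readable step at this place. Read with an at least 2.2-fold lower number from compound 2 to compound 3 (0.34 log units; beyond the scatter), this leaves trifluoromethoxy as the only group shown at this place that gives a number below the assay's limit, since compound 3 lies beyond the scatter from both compound 2 and compound 4, and methoxy and pentyl both end at the limit. The step from compound 2 to compound 4, pentyl in place of methoxy, cannot be read, and the two compounds share the upper end of the range in this assay: the limit of > 500000 nM in this assay, at which 2 of the 4 values shown sit.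

From the compounds shown here alone, how far methoxy and pentyl each lie past that limit stays open, so the series gives no order between these two groups. Also open, going by these compounds, is whether a polar group at the same aromatic carbon, such as an amine or a carboxylic acid, or a longer chain than pentyl, would give a number below the limit, as trifluoromethoxy does in compound 3, or would end at the limit.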